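Solubility of an oxane isomer pair

The compounds below may be only part of what the source reports. "The series", "measured", "known", "first", "only" and "open" are said of these compounds alone.

Measured in a physicochemical assay for solubility (on this read-out higher numbers stand for higher solubility and lower numbers for lower solubility), so far:
Compound 1 `C[C@H](Oc1ccc(S(C)(=O)=O)cc1C(=O)N1Cc2ccc(C(F)(F)F)cc2C1)C(F)(F)F` gives 1 ug/mL
Compound 2 `C[C@H](Oc1ccc(S(C)(=O)=O)cc1C(=O)N1Cc2ccc(C3CCCCO3)cc2C1)C(F)(F)F` gives < 1 ug/mL which is a limit

On these data alone, compound 2 has no number of its own, only a limit, the limit of < 1 ug/mL in this assay, at which 1 of the 2 values shown sits, and its exact place therefore stays open. Compound 3 `C[C@H](Oc1ccc(S(C)(=O)=O)cc1C(=O)N1Cc2ccc(C3CCOCC3)cc2C1)C(F)(F)F` has the same atoms as compound 2, joined differently: oxan-4-yl in place of oxan-2-yl on an aromatic carbon and the shared core stays as it was.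

Within the data shown here, only one measured step bears on this change, a number no higher from compound 1 to compound 2 (the limit leaves the size open) and its size cannot be read. That step replaces trifluoromethyl with oxan-2-yl, so it is not a direct precedent for exchanging oxan-2-yl for oxan-4-yl. Among the measured compounds shown here, no measured pair shows that exchange. The nearest actual number is that of compound 1 at 1 ug/mL and it serves as the anchor. With so little to go on, no change beyond the usual scatter is expected in this assay in either direction. The expected size is a number no lower from compound 2 to compound 3 (the limit leaves the size open) and another limit reading remains quite possible. Compound 3 is estimated at 1 ug/mL with an expected range from 0.5 ug/mL to 4 ug/mL as its likely span.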

Compound 3, solubility: 76 ug/mL
Estimate against measurement, compound 3: 76-fold (1.88 log units) below; the measured number lies above the stated range.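

In this assay, this position proves sensitive not only to which group sits on the aromatic carbon but also to how that group is joined: oxan-4-yl in place of oxan-2-yl gives an at least 76-fold higher number from compound 2 to compound 3 (1.88 log units; beyond the scatter), although the two groups have the same atoms and the same counts of donors and acceptors. The comparison with trifluoromethyl now has a readable size as well, with oxan-4-yl in its place giving a 76-fold higher number from compound 1 to compound 3 (1.88 log units; beyond the scatter), so replacing trifluoromethyl with a six-membered oxygen ring does not have one fixed outcome here. The reading for compound 2 remains a limit and not a number, and the step leading to it cannot be read: the limit of < 1 ug/mL in this assay, at which 1 of the 3 values shown sits.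

On these data alone, whether oxan-3-yl, the same atoms joined in a third way, would read closer to compound 2 or to compound 3 stays open, as does whether cyclohexyl, which lacks the ring oxygen, or morpholine, which brings a ring amine, would match compound 3. All three compounds share one core, so it also remains open whether the exchange of oxan-2-yl for oxan-4-yl would give a similar step on a different core, and the data shown give no measured reason for the split between the two isomers.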